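A few compounds are considered here, and "the series" means these few. Any claim that something is new, unique, unknown or untested is made for them only; others in the source may bear on it.

Measured so far, in a functional assay on HCT-15 cells (Homo sapiens) for inhibition, read by sulforhodamine B assay, with a stated time of 48 h; a higher number here means a weaker inhibitor of growth, a lower number a stronger inhibitor of growth:
compound 1 `O=C(Nc1cccc(-n2cc(-c3ccncc3)c(-c3ccc(Cl)c(O)c3)n2)c1)Nc1cccc(C(F)(F)F)c1` gives 1510 nM
compound 2 `COc1cc(-c2nn(-c3cccc(NC(=O)Nc4cccc(C(F)(F)F)c4)c3)cc2-c2ccncc2)ccc1Cl` gives 870 nM
compound 3 `O=C(Nc1cccc(-n2cc(-c3ccncc3)c(-c3ccc(Cl)c(O)c3)n2)c1)Nc1cc(C(F)(F)F)cc(C(F)(F)F)c1` gives 474 nM

Compound 1 carries the highest number of the three. Its nearest neighbour is compound 2, a 1.7-fold lower number from compound 1 to compound 2 (0.24 log units; within the scatter), a step that stays within the scatter. Further off is compound 3, a 3.2-fold lower number from compound 1 to compound 3 (0.50 log units; beyond the scatter), a modest step beyond the scatter.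

Compound 4 `O=C(Nc1cccc(-n2cc(-c3ccncc3)c(-c3ccc(Cl)c(O)c3)n2)c1)Nc1ccc(Cl)c(C(F)(F)F)c1` is not yet measured. It differs from compound 1 in one place: chloro in place of hydrogen on an aromatic carbon. Among the compounds with values here, the change sits on the same six-membered aromatic ring of carbon only that is also the ring in which compound 3 differs from compound 1, a change that brought the number down modestly. The step from compound 1 to compound 2, methyl in place of hydrogen on an oxygen elsewhere on the shared core, stayed within the scatter and bears less on this case. Adding chloro to that ring is therefore expected to lower the number somewhat, probably by less than the trifluoromethyl did. The expected step is a 2.0-fold lower number from compound 1 to compound 4 (0.30 log units; within the scatter), with a real chance that the result stays within the scatter of compound 1. Compound 4 is estimated at 750 nM, with a range from 320 nM to 1700 nM.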

Compound 4, concentration for 50% growth inhibition: 867 nM
Compound 4: the middle estimate sits 1.2-fold (0.06 log units) below what was measured; measured number inside the range.
By their numbers in this assay, from the lowest: compounds 3, 4, 2 and 1 (each within the scatter of the next, the first and the last beyond it).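

In this assay, chloro in place of hydrogen on this aromatic carbon, ortho to a trifluoromethyl group and para to a large group, gives a 1.7-fold lower number from compound 1 to compound 4 (0.24 log units; within the scatter). The position therefore takes a chloro without a step beyond the scatter, so 4-chloro-3-(trifluoromethyl)phenyl cannot be told apart from 3-(trifluoromethyl)phenyl in this assay, whereas the trifluoromethyl change on the same ring, at a different position, gives a 3.2-fold lower number from compound 1 to compound 3 (0.50 log units; beyond the scatter). Nothing available explains the size of either step on this ring.

The compounds shown leave open whether this position responds to anything at all, since a single chloro is the only group seen there, and a fluoro, a methoxy, an amine or a carboxylic acid at the same carbon would test that more widely. They also leave open whether the chloro, on this same ring, would behave the same way on the core of compound 2, which carries methyl on the oxygen, and whether a chloro in the place of the added trifluoromethyl of compound 3 would reach that compound's number.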